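The source may report more compounds than this note shows. Statements on the series, on what has been measured and on what is new or still open speak of the compounds shown alone.

Measured compounds in the series:

Compound 1 `Cc1c(OCCCCOc2cncc(C(=O)O)c2)ccc(C(=O)CC(C)(C)C)c1O`: 490 nM in an assay for positive allosteric modulation of metabotropic glutamate receptor 2 (Rattus norvegicus); a higher number here means that more compound is needed for the effect, a lower number that less compound is needed
Compound 2 `Cc1ccc(C(=O)O)cc1OCCCCOc1ccc(C(=O)CC(C)(C)C)c(O)c1C`: 512 nM in this assay
Compound 3 `COc1ccc(OCCCCOc2ccc(C(=O)CC(C)(C)C)c(O)c2C)cc1`: only a limit in this assay

Compounds 1 and 2 give numbers in this assay that differ by a 1.0-fold higher number from compound 1 to compound 2 (0.02 log units; within the scatter). Compound 3 stands apart: in this assay compound 3 gives > 10000 nM, which is a limit of the assay and not a number (the limit of > 10000 nM in this assay, at which 1 of the 3 values shown sits). The steps of an at least 20-fold higher number from compound 1 to compound 3 (1.30 log units; beyond the scatter) and an at least 19-fold higher number from compound 2 to compound 3 (1.29 log units; beyond the scatter) are both large, so compound 3 sits at the weak end of what has been measured here.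

The next compound is compound 4 `Cc1c(OCCCCOc2ccc(F)c(C(N)=O)c2)ccc(C(=O)CC(C)(C)C)c1O`. The change from compound 3 is 3-carbamoyl-4-fluorophenyl in place of 4-methoxyphenyl on an oxygen on a saturated carbon. Within the data shown here, the steps that bear on it are the two leading into compound 3, an at least 20-fold higher number from compound 1 to compound 3 (1.30 log units; beyond the scatter) and an at least 19-fold higher number from compound 2 to compound 3 (1.29 log units; beyond the scatter), both taken in the reverse direction: each time a ring with a carboxylic acid was exchanged for the 4-methoxyphenyl, the number rose strongly. Compound 4 reverses the exchange only in part, bringing in a carbamoyl and a fluorine rather than a carboxylic acid. A step downward in this assay from compound 3 to compound 4 is therefore expected, but smaller than the measured ones, and a limit again is possible. For compound 4 the expected value in this assay is 3000 nM, in the range 800 nM to 20000 nM, an expected step of an at least 3.3-fold lower number from compound 3 to compound 4 (0.52 log units; beyond the scatter).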

Compound 4, half-maximal effective concentration: > 10000 nM
Compound 4: only a limit was reported; the forecaster's own chance of this, stated with the estimate: 35%; middle value at least 3.3-fold (0.52 log units) away from the limit.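

In this assay compound 4 gives > 10000 nM, which is a limit of the assay and not a number: the limit of > 10000 nM in this assay, at which 2 of the 4 values shown sit. The change to this ring is costly, with an at least 19-fold higher number from compound 2 to compound 4 (1.29 log units; beyond the scatter) and an at least 20-fold higher number from compound 1 to compound 4 (1.30 log units; beyond the scatter), so at this place, on an oxygen on a saturated carbon, a carbamoyl with a fluorine does not take over from the carboxylic acid rings, and a carbonyl on the ring is not enough for a measurable number. Across the four compounds shown, the two rings with a carboxylic acid give numbers and the two without one give limits, with no compound against this, while the step between compound 3 and compound 4 cannot be read, so the 3-carbamoyl-4-fluorophenyl and the 4-methoxyphenyl stay unordered.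

The carbamoyl and the fluorine enter together in compound 4, which leaves the share of each open. Also open, going by these compounds, is whether a tetrazole or a sulfonic acid on the ring, or a carboxylic acid on the 4-fluorophenyl ring in place of the carbamoyl, would give a number in this assay like those of the acids.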